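This account rests on a few compounds, and the source may have more. Where it says the series, first, only, none or still open, it means among the compounds named here.

Working notes on the thiopyrimidine series in an assay for inhibition of Polyunsaturated fatty acid 5-lipoxygenase (Homo sapiens), tested at 1 uM; on this read-out higher numbers stand for a weaker effect at the one concentration tested and lower numbers for a stronger effect. Compound 1, `CCCCC(Sc1nc(Cl)cc(Nc2ccc3ncccc3c2)n1)C(=O)OCC`, gives 51.8% in this assay. Compound 2, `CCOC(=O)C(C)Sc1nc(Cl)cc(Nc2ccc3ncccc3c2)n1`, is reported in this assay as "not active" (no number reported) without a number. Compound 3, `O=C(O)C(Sc1nc(Cl)cc(Nc2ccc3ncccc3c2)n1)c1ccccc1`, is likewise reported in this assay as "not active" (no number reported) without a number. Compound 2 therefore stands without a single number, and one further entry in the set, compound 3, shares that state; only compound 1 carries a number.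

The step under consideration leads from compound 2 to compound 4, `CCOC(=O)CSc1nc(Cl)cc(Nc2ccc3ncccc3c2)n1`. The change is hydrogen in place of methyl on a saturated chain carbon bound to a carbonyl carbon and a sulfur. Among the measured compounds shown here, no step between measured compounds is available, so the size of this step in this assay cannot be read from a neighbouring pair. Compound 2 gave no number, and nothing in the set shows that taking the methyl away moves the read-out beyond the scatter. The expectation for compound 4 in this assay is a reading of 88%, in the range 65% to 100%, with a fair chance that again only "not active" is reported.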

Compound 4, a percentage reported as activity, at one concentration (the size of the read-out at that concentration, not a potency): 86.3%
Compound 4: middle estimate off by 1.7 percentage points, on the high side; the measured number falls inside the stated range.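

In this assay, the saturated chain carbon bound to a carbonyl carbon and a sulfur now has a reading with hydrogen on it, and replacing butyl with hydrogen there gives a number 34.5 percentage points higher from compound 1 to compound 4 (beyond the scatter), so butyl goes with the stronger effect at the one concentration tested. Compound 2, with methyl at this place, remains at "not active" (no number reported), so the step from methyl to hydrogen cannot be read and the effect of methyl cannot be sized. No measurement in the set accounts for the difference in read-out.

Going by these compounds, whether propyl or hexyl at this carbon would keep the effect seen with butyl remains open. On these data alone, it is also open whether an amide in place of the ethyl ester would keep that effect on the butyl-bearing compound.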